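The source may report more compounds than this note shows. Statements on the series, on what has been measured and on what is new or still open speak of the compounds shown alone.

Working notes on the series. Compound 3 `Cc1c(Cc2ccc(OC(F)(F)F)cc2)c(=O)oc2cc(OCC(O)CN3CCC(C(N)=O)CC3)ccc12` carries a trifluoromethoxy, and in an ADME assay on A549 cells (Homo sapiens) for cytotoxicity, read by CellTiter-Glo (a lower number here means that less compound is tolerated, a higher number that more compound is tolerated), compound 3 gives 68200 nM. Compound 2 `Cc1c(Cc2ccc(C(F)(F)F)cc2)c(=O)oc2cc(OCC(O)CN3CCC(C(N)=O)CC3)ccc12` gives 89300 nM and compound 1 `Cc1c(Cc2ccc(Cl)cc2)c(=O)oc2cc(OCC(O)CN3CCC(C(N)=O)CC3)ccc12` gives 40000 nM; compound 3 is close to both, the differences a 1.3-fold lower number from compound 2 to compound 3 (0.12 log units; within the scatter) and a 1.7-fold higher number from compound 1 to compound 3 (0.23 log units; within the scatter) being within the scatter. Among the measured compounds shown here, the only step beyond the scatter is a 2.2-fold higher number from compound 1 to compound 2 (0.35 log units; beyond the scatter), and it is modest. Compound 4 `COC(=O)c1ccc(Cc2c(C)c3ccc(OCC(O)CN4CCC(C(N)=O)CC4)cc3oc2=O)cc1` differs from compound 3 by methoxycarbonyl in place of trifluoromethoxy on an aromatic carbon. For the measured compounds named here, no measured step brings in a methoxycarbonyl, so the three steps bear on compound 4 only through the narrow spread they show. No step beyond the scatter is expected in this assay; compound 4 is estimated at 60000 nM, with a range of 25000 nM to 150000 nM, which means an expected step of a 1.1-fold lower number from compound 3 to compound 4 (0.06 log units; within the scatter).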

Compound 4, half-maximal cytotoxic concentration: > 100000 nM
Compound 4 ended at the assay's limit; the forecaster's own chance of this, stated with the estimate: 15%; at least 1.6-fold (0.22 log units) between middle value and limit.
By their numbers in this assay, from the lowest: compounds 1, 3 and 2 (each within the scatter of the next, the first and the last beyond it). At a limit, above all of these: compound 4.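

In this assay, among the compounds shown here, compound 4 brings the first halogen-free group to this position, and its reading is a limit and not a number: the limit of > 100000 nM in this assay, at which 1 of the 4 values shown sits. Against chloro, methoxycarbonyl gives an at least 2.5-fold higher number from compound 1 to compound 4 (0.39 log units; beyond the scatter), so a second change at this position clears the scatter, after a 2.2-fold higher number from compound 1 to compound 2 (0.35 log units; beyond the scatter). The floors of an at least 1.4-fold higher number from compound 3 to compound 4 (0.16 log units; that floor lies within the scatter) and an at least 1.1-fold higher number from compound 2 to compound 4 (0.04 log units; that floor lies within the scatter) lie within the scatter, so methoxycarbonyl is not separated from either fluorinated group.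

On these data alone, the true size of these steps remains open. So does the reading at this position with a carboxylic acid, an amine or a longer chain.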